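Swapping propyl for 3-chlorophenyl on the pyrazole carbon

The compounds below may be only part of what the source reports. "The series", "measured", "known", "first", "only" and "open" are said of these compounds alone.

Measured so far in a functional assay on SK-MEL-2 cells (Homo sapiens) for cytotoxicity, read by sulforhodamine B assay, with a stated time of 2 days, tested at 100 uM; a lower number here means less inhibition, a higher number more inhibition at the concentration tested (going by the name of the read-out):
compound 1 `CCCc1n[nH]c2c(=O)n(NC(=O)c3ccncc3)c(-c3cccc(OC)c3)nc12` — 11.4%
compound 2 `COc1cccc(-c2nc3c(-c4ccc(C5CCNCC5)cc4)n[nH]c3c(=O)n2NC(=O)c2ccncc2)c1` — 23.4%
compound 3 `CCCc1n[nH]c2c(=O)n(NC(=O)c3ccccc3)c(-c3cccc(OC)c3)nc12` — 16.7%

Of the compounds shown here, three share one core and have been read in this assay. Compound 3 carries propyl on the five-membered ring and a phenyl on the carbonyl; its value falls within the scatter of both compound 1 and compound 2, so none of the three can be ranked against the others with confidence. Going by the values given here, the one step that goes beyond the scatter is a number 12 percentage points higher from compound 1 to compound 2 (beyond the scatter), where an aromatic group replaces propyl on the same aromatic carbon. The step of a number 5.3 percentage points higher from compound 1 to compound 3 (within the scatter) concerns only the amide and stays within the scatter.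

Compound 4 `COc1cccc(-c2nc3c(-c4cccc(Cl)c4)n[nH]c3c(=O)n2NC(=O)c2ccccc2)c1` is the next compound in the series. Its change from compound 3 is 3-chlorophenyl in place of propyl on an aromatic carbon. This is the same kind of replacement, alkyl to aryl, that the step from compound 1 to compound 2 showed, though the aryl group entering here lacks the piperidine of compound 2. On that single precedent, a modest rise is expected rather than none. Compound 4 is therefore estimated at 26%, with a plausible range from 12% to 42%, which means an expected step of a number 9.3 percentage points higher from compound 3 to compound 4 (within the scatter).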

Compound 4, a percentage reported as inhibition, at one concentration (the size of the read-out at that concentration, not a potency): 81.9%
Compound 4: middle estimate off by 55.9 percentage points, on the low side, outside the stated range (above it).
By their numbers in this assay, from the lowest: compounds 1, 3 and 2 (each within the scatter of the next, the first and the last beyond it); then compound 4.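

In this assay, going by these compounds alone, the aromatic carbon of the five-membered ring proves able to carry a far larger change in the read-out than the earlier compounds indicated, with 3-chlorophenyl in place of propyl giving a number 65.2 percentage points higher from compound 3 to compound 4 (beyond the scatter) in a single replacement. The earlier replacement of propyl at this carbon, by 4-(piperidin-4-yl)phenyl, gave a number 12 percentage points higher from compound 1 to compound 2 (beyond the scatter) with pyridin-4-yl rather than phenyl on the carbonyl, so putting an aryl group here does not by itself set the size of the step, and these compounds cannot separate the effect of the entering aryl group from that of the amide partner. No measurement at hand accounts for the size of the step.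

The compounds shown leave open whether the chlorine is needed at all, which an unsubstituted phenyl at this carbon would test, and whether a longer chain such as butyl would also raise the read-out. They also leave open whether 3-chlorophenyl gives a similar step when pyridin-4-yl sits on the carbonyl, and whether a bromine or a methoxy group could take the place of the chlorine.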